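Methoxy removal on the biphenylmethyl quinolone series

A few compounds are considered here, and "the series" means these few. Any claim that something is new, unique, unknown or untested is made for them only; others in the source may bear on it.

Two compounds of the shared core carry numbers in an assay on isolated protein for inhibition of DNA topoisomerase 1 (Homo sapiens), with a stated time of 15 min; on this read-out higher numbers stand for weaker inhibition and lower numbers for stronger inhibition. Compound 1, `NCCNc1cc2c(cc1F)c(=O)c(C(=O)O)cn2Cc1ccc(-c2ccccc2)cc1`, gives 72800 nM. Compound 2, `CNCCCNc1c(F)cc2c(=O)c(C(=O)O)cn(Cc3ccc(-c4ccccc4)cc3)c2c1OC`, gives 101000 nM in this assay, and its number sits within the usual scatter of that of compound 1, so the two are not told apart by this read-out. Both are weak on this scale.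

Compound 3, `CNCCCNc1cc2c(cc1F)c(=O)c(C(=O)O)cn2Cc1ccc(-c2ccccc2)cc1`, is to be measured in this assay. It differs from compound 2 in one place: hydrogen in place of methoxy on an aromatic carbon, with the (3-(methylamino)propyl)amino group and the fluoro group otherwise kept. Among the measured compounds shown here, no pair of measured compounds isolates this change, so the size of the step has to be guessed from the two values shown, which give no indication that a small change on this ring shifts the number far. The step from compound 2 to compound 3 is expected to be a 1.3-fold lower number from compound 2 to compound 3 (0.10 log units; within the scatter), that is, no more than the scatter, with the direction uncertain. Compound 3 is therefore estimated at 80000 nM in this assay, within a range of 30000 nM to 220000 nM.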

Compound 3, half-maximal inhibitory concentration: 63600 nM
Estimate against measurement, compound 3: 1.3-fold (0.10 log units) above, within the range that was stated.
By their numbers in this assay, from the lowest: compounds 3, 1 and 2 (each within the scatter of the next).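

In this assay hydrogen in place of methoxy, on the aromatic carbon ortho to a (3-(methylamino)propyl)amino group, reads as a 1.6-fold lower number from compound 2 to compound 3 (0.20 log units; within the scatter) and so leaves the two compounds untold apart at this position. Among the compounds shown here, this is the first pair to isolate this exchange, since compound 1 and compound 2 differ in more than one place, and it shows that methoxy at this carbon is not needed to hold the number in this weak range. The second pair isolates the chain: (methylamino)methyl in place of amino on a saturated chain carbon, two bonds along the chain from a nitrogen on an aromatic ring, reads as a 1.1-fold lower number from compound 1 to compound 3 (0.06 log units; within the scatter) and likewise separates nothing, and no supporting data bear on the reason for either reading.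

From the compounds shown here alone, whether a chloro or an ethoxy group on this aromatic carbon, or a longer chain ending in a dimethylamino group, would stand apart from compound 3 remains open. Also open, going by these compounds, is whether a primary amide in place of the carboxylic acid, which all three compounds share, would move the number beyond the scatter.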